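A trifluoromethyl-for-chloro swap carried onto a second core

The source may report more compounds than this note shows. Statements on the series, on what has been measured and on what is new or still open speak of the compounds shown alone.

The study compares three measured compounds and one awaiting measurement. Compound 1 `CC(=O)N1CCN(c2cc(-c3cc(Cl)c4c(N)ncnn34)ccc2C(F)(F)F)C(=O)C1(C)C`, compound 2 `CC(=O)N1CCN(c2cc(-c3cc(Cl)c4c(N)ncnn34)ccc2Cl)C(=O)C1(C)C` and compound 3 `CC(=O)N1C[C@@H](C)N(c2cc(-c3cc(Cl)c4c(N)ncnn34)ccc2C#N)C(=O)C1(C)C` were tested in an ADME assay on microsomes from liver (Homo sapiens) for metabolic stability, read by LC-MS, using NADPH, with stated times of 6 min and 10 min, tested at 0.5 uM; on this read-out lower numbers stand for a less stable compound and higher numbers for a more stable compound. Compound 1 gives 95%, compound 2 gives 85% and compound 3 gives 82%. Compound 2 and compound 1 differ in one change, (trifluoromethyl in place of chloro on an aromatic carbon), and the step from compound 2 to compound 1 was a number 10 percentage points higher from compound 2 to compound 1 (within the scatter).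

Compound 4 `CC(=O)N1C[C@@H](C)N(c2cc(-c3cc(C(F)(F)F)c4c(N)ncnn34)ccc2C#N)C(=O)C1(C)C` arises from compound 3 by the same kind of change, (trifluoromethyl in place of chloro on an aromatic carbon). The two places differ: in compound 1 the group sits on a six-membered aromatic ring of carbon only, ortho to a large group and para to a large group, whereas in compound 4 it sits on a five-membered aromatic ring with 1 nitrogen, part of a fused or bridged system of two rings. The difference between the cores of compound 3 and compound 2 is not broken down here.

Resting on the step from compound 2 to compound 1, a number 10 percentage points higher from compound 2 to compound 1 (within the scatter), the step from compound 3 to compound 4 in this assay is expected to be a number 5 percentage points higher from compound 3 to compound 4 (within the scatter). Compound 4 is therefore estimated at 87%, with a likely range from 75% to 97%.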

Compound 4, percent of the compound remaining: 90%
Estimate against measurement, compound 4: 3 percentage points below, and the stated range covers the measured number.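

In this assay, trifluoromethyl in place of chloro gave a number 8 percentage points higher from compound 3 to compound 4 (within the scatter). Set beside the earlier step, the change reads alike on both cores: the same change on two cores in this assay, a number 10 percentage points higher (within the scatter) from compound 2 to compound 1 and a number 8 percentage points higher (within the scatter) from compound 3 to compound 4, 2 percentage points apart, within the scatter of two such steps

This shows agreement between two cores, one with the group on a six-membered aromatic ring and one with it on a five-membered aromatic ring, but each step lies within the scatter, so it does not show that the change makes a compound more stable on either core, nor does it make a rule for the whole series.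

The compounds shown leave open how a methoxy group or an amine in the same place would read in this assay. They also leave open whether the agreement would hold on a third core.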